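A few compounds are considered here, and "the series" means these few. Any claim that something is new, unique, unknown or untested is made for them only; others in the source may bear on it.

Measured so far:
compound 1 `CCOC(=O)c1c(C)[nH]c(=O)c(C#N)c1-c1ccccc1` — in a functional assay on HepG2 cells (Homo sapiens) for inhibition, read by MTT assay, with a stated time of 24 h (on this read-out lower numbers stand for stronger inhibition and higher numbers for weaker inhibition), compound 1 gives 38500 nM;
compound 2 `CCOC(=O)c1c(C)[nH]c(=O)c(C#N)c1-c1ccc(C)cc1` — in this assay compound 2 gives 11900 nM;
compound 3 `CCOC(=O)c1c(C)[nH]c(=O)c(C#N)c1-c1ccccc1Cl` — in this assay compound 3 gives 34100 nM.

Compound 3 stands second highest of the three numbers: compound 1 sits within the scatter of it, whereas a 2.9-fold higher number from compound 2 to compound 3 (0.46 log units; beyond the scatter) is a modest step beyond the scatter. The aryl changes seen so far are a 3.2-fold lower number from compound 1 to compound 2 (0.51 log units; beyond the scatter) and a 1.1-fold lower number from compound 1 to compound 3 (0.05 log units; within the scatter).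

Compound 4 `CCOC(=O)c1c(C)[nH]c(=O)c(C#N)c1-c1cccs1` carries the change (thiophen-2-yl in place of 2-chlorophenyl on an aromatic carbon). For the measured compounds named here, no measured step swaps the six-membered aromatic ring for a five-membered one, so the only guide is the spread of the aryl variants, which lies within a modest band. For compound 4 the expected step is a 1.1-fold lower number from compound 3 to compound 4 (0.06 log units; within the scatter), i.e. no shift clearly beyond the scatter. Compound 4 is therefore estimated at 30000 nM, with a range of 12000 nM to 80000 nM.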

Compound 4, half-maximal inhibitory concentration: 74100 nM
Estimate against measurement, compound 4: 2.5-fold (0.39 log units) below; the range from low to high includes it.
By their numbers in this assay, from the lowest: compound 2; then compounds 3, 1 and 4 (each within the scatter of the next, the first and the last beyond it).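

At the aryl position opposite the ring nitrogen, the five-membered thiophen-2-yl gives the first ring change read in this assay, and its steps are uneven: two lie beyond the scatter (a 2.2-fold higher number from compound 3 to compound 4 (0.34 log units; beyond the scatter); a 6.2-fold higher number from compound 2 to compound 4 (0.79 log units; beyond the scatter)), whereas the step from phenyl stays within it (a 1.9-fold higher number from compound 1 to compound 4 (0.28 log units; within the scatter)). Swapping phenyl for thiophen-2-yl thus gives no shift clearly beyond the scatter, and 4-methylphenyl in compound 2 keeps the lowest number. No evidence on the cause of these steps is available.

Open: whether an aminophenyl or carboxyphenyl group, or a furan-2-yl ring, at this position would lower the number beyond that of compound 2.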